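This account rests on a few compounds, and the source may have more. Where it says the series, first, only, none or still open, it means among the compounds named here.

Measured compounds:
compound 1, `COc1ccc(CNc2nc([SeH])nc3ccccc23)cc1`, 37400 nM
compound 2, `[SeH]c1nc(NCc2ccccc2)c2ccccc2n1`, 3540 nM
compound 3, `CSc1nc(NCc2ccccc2)c2ccccc2n1`, 38900 nM

In an ADME assay on BEAS-2B cells (Homo sapiens) for cytotoxicity, read by MTT assay, with a stated time of 72 h (a lower number here means a stronger inhibitor of growth, a higher number a weaker inhibitor of growth), compound 2 gives the lowest number of the three. Compound 1 differs from compound 2 by methoxy in place of hydrogen on an aromatic carbon, and this change gives an 11-fold higher number from compound 2 to compound 1 (1.02 log units; beyond the scatter). The two cores differ by a group of 2 heavy atoms (1 carbon, 1 sulfur; no ring) in place of one selenium atom, on an aromatic carbon, with a step of an 11-fold higher number from compound 2 to compound 3 (1.04 log units; beyond the scatter); compound 1 and compound 3 give numbers within the scatter of each other, so no order between them is claimed.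

Compound 4, `COc1ccc(CNc2nc(SC)nc3ccccc23)cc1`, is not yet measured. It differs from compound 3 by methoxy in place of hydrogen on an aromatic carbon, the same change as from compound 2 to compound 1, made here on the core of compound 3. With one prior example of this change and a different core, the expected step in this assay is set smaller than an 11-fold higher number from compound 2 to compound 1 (1.02 log units; beyond the scatter), at a 2.6-fold higher number from compound 3 to compound 4 (0.41 log units; beyond the scatter), because compound 3 already stands at 38900 nM. Compound 4 is therefore estimated at 100000 nM, with a range from 40000 nM to 400000 nM.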

Compound 4, concentration for 50% growth inhibition: 21700 nM
Compound 4: middle estimate off by 4.6-fold (0.66 log units), on the high side; the measured number lies below the stated range.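

In this assay, methoxy in place of hydrogen on an aromatic carbon does not carry over from one core to the other, and the two steps differ: the same change on two cores in this assay, an 11-fold higher number (1.02 log units; beyond the scatter) from compound 2 to compound 1 and a 1.8-fold lower number (0.25 log units; within the scatter) from compound 3 to compound 4, 19-fold (1.28 log units) apart, beyond the scatter of two such steps. The exchange of selenium for the group of 2 heavy atoms (1 carbon, 1 sulfur; no ring) also fails to carry over: the same change on two cores in this assay, an 11-fold higher number (1.04 log units; beyond the scatter) from compound 2 to compound 3 and a 1.7-fold lower number (0.24 log units; within the scatter) from compound 1 to compound 4, 19-fold (1.28 log units) apart, beyond the scatter of two such steps. On the core of compound 3, methoxy gives a 1.8-fold lower number from compound 3 to compound 4 (0.25 log units; within the scatter), and on the methoxy-bearing core the selenium exchange gives a 1.7-fold lower number from compound 1 to compound 4 (0.24 log units; within the scatter); both steps stay within the scatter, so the two changes do not add up across these four compounds, but this single set shows neither why that is so nor whether it holds on any other core.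

The compounds shown leave open whether the result on compound 2 is tied to selenium itself, since a free thiol or a longer chain on sulfur is not among them. They also leave open whether other groups in place of methoxy, such as an amine or a carboxylic acid, would behave in the same way on both cores.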